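The source may report more compounds than this note shows. Statements on the series, on what has been measured and on what is new or still open speak of the compounds shown alone.

Working notes on the series. Compound 1 `C[C@@H](CF)OC(=O)N1CCC(O[C@H]2CC[C@H](Oc3cnc(S(C)(=O)=O)cn3)CC2)CC1` in a functional assay on isolated protein for agonist activity at Glucose-dependent insulinotropic receptor (Rattus norvegicus), read by HTRF and cAMP accumulation (on this read-out higher numbers stand for an effect only at larger amounts of compound and lower numbers for an effect already at smaller amounts), gives 356 nM. Compound 2 `CS(=O)(=O)c1cnc(O[C@H]2CC[C@H](OC3CCN(C(=O)OC4CCOC4)CC3)CC2)cn1` in this assay gives 1500 nM. Compound 3 `CS(=O)(=O)c1cnc(O[C@H]2CC[C@H](OC3CCN(CC4(C(F)(F)F)CCC4)CC3)CC2)cn1` in this assay gives 80 nM, the lowest of the three numbers; its distance from the others is shown by a 4.5-fold lower number from compound 1 to compound 3 (0.65 log units; beyond the scatter) and a 19-fold lower number from compound 2 to compound 3 (1.27 log units; beyond the scatter), both beyond the scatter.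

Compound 4 `CS(=O)(=O)c1cnc(O[C@H]2CC[C@H](OC3CCN(CC4(C(F)(F)F)CCCC4)CC3)CC2)cn1` differs from compound 3 by a group of 9 heavy atoms (6 carbon, 3 fluorine; one five-membered non-aromatic ring of carbon only) in place of a group of 8 heavy atoms (5 carbon, 3 fluorine; one four-membered non-aromatic ring of carbon only), on a saturated chain carbon bound to an amine nitrogen in a ring. Within the data shown here, no measured step changes the ring carried on this chain carbon: a 4.5-fold lower number from compound 1 to compound 3 (0.65 log units; beyond the scatter) and a 19-fold lower number from compound 2 to compound 3 (1.27 log units; beyond the scatter) exchange the entire group on the amine nitrogen, and a 4.2-fold higher number from compound 1 to compound 2 (0.62 log units; beyond the scatter) concerns a different position, so none bears directly on a ring enlargement alone. With both neighbours of compound 3 carrying unrelated groups, the expected step is small, within the scatter, namely a 1.1-fold higher number from compound 3 to compound 4 (0.03 log units; within the scatter). For compound 4 the estimate in this assay is 85 nM, with a range of 35 nM to 200 nM.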

Compound 4, half-maximal effective concentration: 101 nM
Compound 4: the middle estimate sits 1.2-fold (0.07 log units) below what was measured, and the stated range covers the measured number.
By their numbers in this assay, from the lowest: compounds 3 and 4 (each within the scatter of the next); then compound 1; then compound 2.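

The five-membered ring in place of 1-(trifluoromethyl)cyclobutyl gives a 1.3-fold higher number from compound 3 to compound 4 (0.10 log units; within the scatter) in this assay, so this place on a saturated chain carbon bound to an amine nitrogen in a ring tolerates the ring enlargement within the scatter. The gain over the other groups on the amine nitrogen persists with the larger ring, as a 15-fold lower number from compound 2 to compound 4 (1.17 log units; beyond the scatter) and a 3.5-fold lower number from compound 1 to compound 4 (0.55 log units; beyond the scatter) show. No supporting data explain these results.

From the compounds shown here alone, a six-membered carbon ring at this place remains open. So does whether a methyl in place of trifluoromethyl would keep the number.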